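The source may hold more compounds than are shown below. What is called first, only, known or untested is meant among the compounds shown, and "the series" means these compounds.

In a functional assay on M21 cells (Homo sapiens) for antiproliferative activity, with a stated time of 48 h (on this read-out lower numbers stand for stronger inhibition and higher numbers for weaker inhibition), compound 1 `CCCCC(O)c1cccc(NC(=O)NCCCCl)c1` gives 35000 nM. Compound 2 `CCCCC(OC)c1cccc(NC(=O)NCCCCl)c1` carries methyl in place of hydrogen on an oxygen on a saturated carbon and in this assay gives 51000 nM, a step of a 1.5-fold higher number from compound 1 to compound 2 (0.16 log units; within the scatter). Compound 3 `CCCCC(O)c1cccc(NC(=O)CCCCl)c1` differs from compound 1 by 3-chloropropyl in place of (3-chloropropyl)amino on a carbonyl carbon. In this assay compound 3 gives > 100000 nM, which is a limit of the assay and not a number, sitting at the limit of > 100000 nM in this assay, at which 1 of the 3 values shown sits. The step from compound 1 is an at least 2.8-fold higher number from compound 1 to compound 3 (0.45 log units; beyond the scatter). Compound 4 `CCCCC(OC)c1cccc(NC(=O)CCCCl)c1` has no value here yet; it differs from compound 3 by methyl in place of hydrogen on an oxygen on a saturated carbon, the same change at the same place as from compound 1 to compound 2. The expected step that the limit leaves unreadable from compound 3 to compound 4 is estimated small because a 1.5-fold higher number from compound 1 to compound 2 (0.16 log units; within the scatter) stayed within the scatter. Compound 4 is therefore expected near 150000 nM, between 80000 nM and 400000 nM, most likely again only a limit.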

Compound 4, half-maximal inhibitory concentration: > 100000 nM
Compound 4 was reported as a limit (the forecaster's own chance of this, stated with the estimate: 80%); the middle value is on the limit's open side.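

On the core of compound 2, the swap of (3-chloropropyl)amino for 3-chloropropyl on the carbonyl carbon gives an at least 1.9-fold higher number from compound 2 to compound 4 (0.29 log units; that floor lies within the scatter) in this assay. Carrying this change over from the core of compound 1 is therefore not contradicted, but the size of its effect on each core is not established: the same change on two cores in this assay, an at least 2.8-fold higher number (0.45 log units; beyond the scatter) from compound 1 to compound 3 and an at least 1.9-fold higher number (0.29 log units; that floor lies within the scatter) from compound 2 to compound 4; the limit leaves it open whether they differ. The hydroxy to methoxy step from compound 3 to compound 4 cannot be read, since both compounds give a limit of the assay and not a number: the limit of > 100000 nM in this assay, at which 2 of the 4 values shown sit.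

Going by these compounds, the true values of compound 3 and compound 4 remain open. So does how a longer chain in place of 3-chloropropyl, or an amine in place of its chlorine, would read in this series.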